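Methoxy added to a benzothiazole-free core: expected step

A few compounds are considered here, and "the series" means these few. Any claim that something is new, unique, unknown or untested is made for them only; others in the source may bear on it.

Compound 1 `COc1ccc(-c2cc(C(=O)Nc3nc4ccc(F)cc4s3)nc3cc(-c4ccccc4)nn23)cc1` and compound 2 `COc1ccc(-c2cc(C(=O)Nc3nc4ccc(F)cc4s3)nc3cc(-c4ccccc4)nn23)cc1OC` share a core and differ by one change, (methoxy in place of hydrogen on an aromatic carbon). In a functional assay on MCF7 cells (Homo sapiens) for cytotoxicity, read by MTT assay, with a stated time of 48 h (a lower number here means a stronger inhibitor, a higher number a weaker inhibitor), compound 1 gives 35500 nM, and compound 2 gives 22400 nM. That change made a 1.6-fold lower number from compound 1 to compound 2 (0.20 log units; within the scatter).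

Compound 3 `COc1ccc(-c2cc(C(=O)Nc3nc4ccccc4s3)nc3cc(-c4ccccc4)nn23)cc1` differs from compound 1 by hydrogen in place of fluoro on an aromatic carbon. In this assay compound 3 gives 2230 nM, a step of a 16-fold lower number from compound 1 to compound 3 (1.20 log units; beyond the scatter), and compound 3 has the lowest number of the three measured compounds.

Compound 4 `COc1ccc(-c2cc(C(=O)Nc3nc4ccccc4s3)nc3cc(-c4ccccc4)nn23)cc1OC` has not yet been measured. Among the compounds with values here, it differs from compound 3 by methoxy in place of hydrogen on an aromatic carbon, the same change as the one from compound 1 to compound 2, made at a place described in the same words. The expectation therefore rests on that earlier step: because a 1.6-fold lower number from compound 1 to compound 2 (0.20 log units; within the scatter) stayed within the scatter, the step from compound 3 to compound 4 is expected to be of similar size, a 1.5-fold lower number from compound 3 to compound 4 (0.17 log units; within the scatter). Compound 4 is accordingly estimated at 1500 nM, with a range from 500 nM to 5000 nM.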

Compound 4, half-maximal inhibitory concentration: 14700 nM
Compound 4: the middle estimate sits 9.8-fold (0.99 log units) below what was measured; measured number above the stated range.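

On the core without fluoro, the change from 4-methoxyphenyl to 3,4-dimethoxyphenyl gave a 6.6-fold higher number from compound 3 to compound 4 (0.82 log units; beyond the scatter) in this assay, so the methoxy step did not carry over from the fluoro core: the same change on two cores in this assay, a 1.6-fold lower number (0.20 log units; within the scatter) from compound 1 to compound 2 and a 6.6-fold higher number (0.82 log units; beyond the scatter) from compound 3 to compound 4, 10-fold (1.02 log units) apart, beyond the scatter of two such steps. The same four compounds can be read the other way round, and the swap of fluoro for hydrogen gave a 1.5-fold lower number from compound 2 to compound 4 (0.18 log units; within the scatter) with the added methoxy in place, which also fails to match the earlier swap: the same change on two cores in this assay, a 16-fold lower number (1.20 log units; beyond the scatter) from compound 1 to compound 3 and a 1.5-fold lower number (0.18 log units; within the scatter) from compound 2 to compound 4, 10-fold (1.02 log units) apart, beyond the scatter of two such steps. This shows that in this small set the two changes do not add up independently, so a step measured on one core is a poor guide to the other, but it does not show why, and it rests on a single pair of steps for each change.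

The compounds shown leave open whether an ethoxy group or an amine at that same place would also behave differently on the two cores. They also leave open whether chloro in place of fluoro would give the same pattern.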